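Swapping the Group on Sulfur: From Compound 3 to Compound 4

The source may report more compounds than this note shows. Statements on the series, on what has been measured and on what is new or still open speak of the compounds shown alone.

Measured in a functional assay on HepG2 cells (Homo sapiens) for cytotoxicity, read by MTT assay, with a stated time of 48 h; a higher number here means a weaker inhibitor, a lower number a stronger inhibitor:
- Compound 1 `CC1=NN(C(=O)CSc2ccccn2)[C@@H](c2cc(Br)cc(Br)c2O)C1`: 24700 nM
- Compound 2 `O=C(CSc1ccc([N+](=O)[O-])cc1)N1N=C(c2cc3ccccc3oc2=O)C[C@@H]1c1ccccc1C(F)(F)F`: 7700 nM
- Compound 3 `O=C(CSCc1ccco1)N1N=C(c2cc3ccccc3oc2=O)C[C@@H]1c1ccccc1C(F)(F)F`: 18000 nM

Compound 3 cannot be told apart from compound 1 within the usual scatter, while compound 2 has a clearly lower number, which means a stronger inhibitor. Compound 4 `O=C(CSc1ccc(Br)cc1)N1N=C(c2cc3ccccc3oc2=O)C[C@@H]1c1ccccc1C(F)(F)F` has not yet been measured. It carries 4-bromophenyl in place of (furan-2-yl)methyl on a sulfur.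

Within the data shown here, one measured step bears on this change: a 2.3-fold higher number from compound 2 to compound 3 (0.37 log units; beyond the scatter). There, (furan-2-yl)methyl took the place of 4-nitrophenyl on a sulfur, a modest step but beyond the scatter. Read backwards, it suggests a lower number when a six-membered aromatic ring of carbon only returns to that sulfur. Among the measured compounds shown here, a single step is thin evidence, and no measured compound yet carries 4-bromophenyl. A modest drop in this assay is therefore expected, and the estimated change is a 2.0-fold lower number from compound 3 to compound 4 (0.30 log units; within the scatter). Compound 4 is expected at 9000 nM, within an estimated range of 4000 nM to 20000 nM.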

Compound 4, half-maximal inhibitory concentration: 17900 nM
Estimate against measurement, compound 4: 2.0-fold (0.30 log units) below; the measured number falls inside the stated range.
By their numbers in this assay, from the lowest: compound 2; then compounds 4, 3 and 1 (each within the scatter of the next).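

In this assay, the step gives a 1.0-fold lower number from compound 3 to compound 4 (0.00 log units; within the scatter) so on this sulfur, 4-bromophenyl and (furan-2-yl)methyl cannot be told apart, and a six-membered aromatic ring of carbon only does not by itself lower the number. The group carried on that ring does matter between the two compounds that share this ring: bromo in place of nitro on an aromatic carbon gives a 2.3-fold higher number from compound 2 to compound 4 (0.37 log units; beyond the scatter) and so the stronger result of compound 2 goes with its nitro group rather than with the ring alone. Nothing measured here gives a reason for either step.

Still open, as far as these compounds go, is whether an amine or a carboxylic acid on the same ring would give a number close to that of compound 2 or of compound 4. A plain phenyl on the sulfur, or a longer chain leading to the ring, also remains to be placed in this series.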